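This account rests on a few compounds, and the source may have more. Where it says the series, first, only, none or still open, it means among the compounds named here.

Measured so far in a functional assay on HL-60 cells (Homo sapiens) for antiproliferative activity, read by MTT assay, with a stated time of 6 days; on this read-out higher numbers stand for weaker inhibition and lower numbers for stronger inhibition
- compound 1 `O=C1C=C[C@@H](OCc2ccccc2)[C@@H]([C@@H](COC(=O)/C=C/c2ccccc2)OCc2ccccc2)O1` gives 610 nM
- compound 2 `COc1ccc(/C=C/C(=O)OC[C@@H](OCc2ccccc2)[C@H]2OC(=O)C=C[C@H]2OCc2ccccc2)cc1` gives 1570 nM
- compound 3 `O=C1C=C[C@@H](OCc2ccccc2)[C@@H]([C@@H](COC(=O)/C=C/c2ccc(F)cc2)OCc2ccccc2)O1` gives 5400 nM

Compound 3 has the highest number of the three, with an 8.9-fold higher number from compound 1 to compound 3 (0.95 log units; beyond the scatter) and a 3.4-fold higher number from compound 2 to compound 3 (0.54 log units; beyond the scatter) both beyond the scatter. Compound 4 `O=C1C=C[C@@H](OCc2ccccc2)[C@@H]([C@@H](CO)OCc2ccccc2)O1` differs from compound 3 as follows (hydrogen in place of (2-(4-fluorophenyl)ethenyl)carbonyl on an oxygen on a saturated carbon). The same difference reads ((2-(4-fluorophenyl)ethenyl)carbonyl)oxy to hydroxy.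

Among the measured compounds shown here, no measured step removes this group. The nearest evidence is a 2.6-fold higher number from compound 1 to compound 2 (0.41 log units; beyond the scatter) and an 8.9-fold higher number from compound 1 to compound 3 (0.95 log units; beyond the scatter), along with the same comparison of a 3.4-fold higher number from compound 2 to compound 3 (0.54 log units; beyond the scatter). These steps exchange only a substituent on an aromatic carbon, so they show the size of change seen so far in this assay but give no direction for this loss. The expected outcome is therefore a 1.8-fold lower number from compound 3 to compound 4 (0.26 log units; within the scatter), and this estimate carries wide uncertainty in either direction. Compound 4 is expected at about 3000 nM, with an estimated range from 600 nM to 15000 nM.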

Compound 4, half-maximal inhibitory concentration: 10200 nM
Compound 4: middle estimate off by 3.4-fold (0.53 log units), on the low side, within the range that was stated.
By their numbers in this assay, from the lowest: compound 1; then compound 2; then compounds 3 and 4 (each within the scatter of the next).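

In this assay, among the compounds shown here, the loss of the whole acyl group on the oxygen on a saturated carbon gives a step that the earlier compounds did not offer, and its size depends on which ester is the starting point. With a 17-fold higher number from compound 1 to compound 4 (1.22 log units; beyond the scatter) and a 6.5-fold higher number from compound 2 to compound 4 (0.81 log units; beyond the scatter) the hydroxy compound stands apart from the unsubstituted and methoxy esters, whereas a 1.9-fold higher number from compound 3 to compound 4 (0.28 log units; within the scatter) leaves the fluoro ester not separable from it, so compound 3 goes against any general benefit of the ester. No measurement at hand accounts for these differences.

Open, from the compounds shown here alone, is whether the benefit requires the ethenyl unit and the aromatic ring at all, which a plain acetyl ester would test against compound 4. Also open, going by these compounds, is how an amine or a carboxylic acid on the aromatic ring would place such an ester relative to compound 1.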